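This account rests on a few compounds, and the source may have more. Where it says the series, first, only, none or still open, it means among the compounds named here.

Measured compounds in an assay on CHO cells for displacement of a labelled ligand from adenosine receptor A1 (Homo sapiens), read by scintillation counting, with a stated time of 120 min, tested at 10 uM; on this read-out higher numbers stand for more inhibition at the one concentration tested (going by the name of the read-out) and lower numbers for less inhibition:
- compound 1 `COc1ccc(N2CCN(Cc3csc(N)c3C(=O)c3ccc(Cl)cc3)CC2)cc1`: 0%
- compound 2 `Nc1scc(CN2CCN(C3CCCCCC3)CC2)c1C(=O)c1ccc(Cl)cc1`: 0%
- compound 3 `Nc1scc(CN2CCN(c3cc(F)cc(F)c3)CC2)c1C(=O)c1ccc(Cl)cc1`: 0%

Compound 3 stands level with compounds 1 and 2 at the digits shown. The steps of no change at the digits printed from compound 1 to compound 3 (within the scatter) and no change at the digits printed from compound 2 to compound 3 (within the scatter) both lie within the scatter, as does no change at the digits printed from compound 1 to compound 2 (within the scatter). Whatever group has stood on the amine nitrogen in the ring, the read-out has not moved.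

Compound 4 `Nc1scc(CN2CCN(c3cc(F)ccc3F)CC2)c1C(=O)c1ccc(Cl)cc1` differs from compound 3 by 2,5-difluorophenyl in place of 3,5-difluorophenyl on an amine nitrogen in a ring. This again exchanges the group on that ring nitrogen, and the two groups carry the same atoms. All three measured steps bear on such an exchange and none moved the value, so no step beyond the scatter is expected in this assay. Compound 4 is therefore estimated at 0% (range -8% to 10%), the expected step being no change at the digits printed from compound 3 to compound 4 (within the scatter).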

Compound 4, a percentage reported as inhibition, at one concentration (the size of the read-out at that concentration, not a potency): 1%
Beside the measured number, compound 4's estimate is 1 percentage points below it; measured number inside the range.
By their numbers in this assay, from the lowest: compounds 1, 2, 3 and 4 (each within the scatter of the next).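

In this assay, exchanging 3,5-difluorophenyl for 2,5-difluorophenyl on the amine nitrogen in the ring, with the same atoms joined differently, gives a step within the scatter (a number 1 percentage points higher from compound 3 to compound 4 (within the scatter)). The 2,5-difluorophenyl group also stays within the scatter of the cycloheptyl and 4-methoxyphenyl groups (a number 1 percentage points higher from compound 2 to compound 4 (within the scatter); a number 1 percentage points higher from compound 1 to compound 4 (within the scatter)), so the placing of the two fluorines on this ring is now a further change at this position with no visible effect on the read-out. No supporting evidence bears on this result.

Going by these compounds, whether a carboxylic acid or a longer alkyl chain on that ring nitrogen would move the read-out remains open. So does the effect of replacing the chlorine on the shared core.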